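Fluoro in place of an amide on the shared core

This account rests on a few compounds, and the source may have more. Where it says the series, first, only, none or still open, it means among the compounds named here.

Compound 1 `CN1CCC[C@H]1COc1cccnc1`: 0.15 nM
Compound 2 `Cc1cncc(OC[C@@H]2CCCN2C)c1`: 0.48 nM
Compound 3 `CN1CCC[C@H]1COc1cncc(C(=O)N2CCCC2)c1`: 19.9 nM

In an assay on membranes from brain for displacement of a labelled ligand from Neuronal acetylcholine receptor; alpha4/beta2 (Rattus norvegicus) (a lower number here means a stronger inhibitor, a higher number a weaker inhibitor), compound 3 gives the highest of the three numbers; its nearest neighbour is compound 2, the furthest compound 1. The steps of a 130-fold higher number from compound 1 to compound 3 (2.12 log units; beyond the scatter) and a 41-fold higher number from compound 2 to compound 3 (1.62 log units; beyond the scatter) were both large, whereas the step of a 3.2-fold higher number from compound 1 to compound 2 (0.51 log units; beyond the scatter) was only modest. Compound 4 `CN1CCC[C@H]1COc1cncc(F)c1` differs from compound 3 by fluoro in place of (pyrrolidin-1-yl)carbonyl on an aromatic carbon, so the bulky group that set compound 3 apart is removed and a single small atom takes its place, as hydrogen and methyl do in compound 1 and compound 2. The expected step is therefore large and downward, a 50-fold lower number from compound 3 to compound 4 (1.70 log units; beyond the scatter). Compound 4 is estimated at 0.4 nM in this assay, with a range from 0.1 nM to 1.6 nM.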

Compound 4, inhibition constant: 0.69 nM
Compound 4: the middle estimate sits 1.7-fold (0.24 log units) below what was measured; the measured number falls inside the stated range.
By their numbers in this assay, from the lowest: compound 1; then compounds 2 and 4 (each within the scatter of the next); then compound 3.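

In this assay, fluoro in place of (pyrrolidin-1-yl)carbonyl reverses most of the loss seen with that group (a 29-fold lower number from compound 3 to compound 4 (1.46 log units; beyond the scatter)), so a substituent at this position need not cost as much as the amide did. Fluoro and methyl are not separated here (a 1.4-fold higher number from compound 2 to compound 4 (0.16 log units; within the scatter)), while hydrogen remains distinct from fluoro (a 4.6-fold higher number from compound 1 to compound 4 (0.66 log units; beyond the scatter)). Nothing further is available to explain these steps. Open, as far as these compounds go, is where an amine or a carboxylic acid at this position would fall. Also open, from the compounds shown here alone, is whether a smaller amide, such as the primary carboxamide, would fare better than the pyrrolidinyl amide.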